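The compounds below may be only part of what the source reports. "The series", "measured", "known", "first", "only" and "open" are said of these compounds alone.

Compound 2 `O=C(O)c1ccccc1-c1ccc(CCc2ncc(Cc3ccccc3Cl)[nH]2)cc1` gives the lowest number of the three measured compounds in an in vitro functional assay on cells for agonist activity at Bombesin receptor subtype-3 (Mus musculus), read by luminescence and calcium flux (on this read-out higher numbers stand for an effect only at larger amounts of compound and lower numbers for an effect already at smaller amounts), at 22 nM. Compound 1 `CCCCc1cnc(C(CCC)Cc2ccc(-c3ccccc3C(=O)O)cc2)[nH]1` gives 165 nM in this assay, and compound 3 `CCCCc1cnc(C(CC)Cc2ccc(-c3ccccc3C(=O)O)cc2)[nH]1` gives 340 nM in this assay. Compound 4 `CC(C)(C)c1cnc(CCc2ccc(-c3ccccc3C(=O)O)cc2)[nH]1` has not yet been measured. Compound 4 differs from compound 2 in one place: tert-butyl in place of 2-chlorobenzyl on an aromatic carbon.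

For the measured compounds named here, no measured step exchanges an aromatic group for an alkyl group on the five-membered aromatic ring, so no step bears directly on this change. Going by the values given here, the only measured step, a 2.1-fold higher number from compound 1 to compound 3 (0.31 log units; beyond the scatter), concerns a different part of the molecule, a saturated chain carbon three bonds along the chain from an aromatic carbon, and shows that a smaller group there gave a higher number. Compound 1, which carries an alkyl group on the five-membered aromatic ring, sits well above compound 2 in its number, though it also differs from compound 2 elsewhere, so that gap cannot be assigned to one change. With a smaller group entering and no branch on the chain, a rise in the number is expected for compound 4, of the size an 18-fold higher number from compound 2 to compound 4 (1.26 log units; beyond the scatter). The expected value for compound 4 in this assay is 400 nM, with a range from 100 nM to 1600 nM.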

Compound 4, half-maximal effective concentration: 2750 nM
Compound 4: the middle estimate sits 6.9-fold (0.84 log units) below what was measured, and the stated range ends below it.
By their numbers in this assay, from the lowest: compound 2; then compound 1; then compound 3; then compound 4.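

In this assay, for the compounds shown here, tert-butyl in place of 2-chlorobenzyl on an aromatic carbon of the five-membered aromatic ring gives a 130-fold higher number from compound 2 to compound 4 (2.10 log units; beyond the scatter) and is the first measured change at this position. This step is far larger than the only earlier one, a 2.1-fold higher number from compound 1 to compound 3 (0.31 log units; beyond the scatter) in a different part of the molecule, so the group on this aromatic carbon has a strong bearing on the number in this series. Nothing available accounts for the size of this step.

The group that leaves differs from the one that enters in several ways at once, having a six-membered aromatic ring, a chlorine and more heavy atoms, so this single step cannot show which of these differences matters. The compounds shown leave open whether unsubstituted benzyl or cyclohexylmethyl at this position would give a number nearer that of compound 2 or that of compound 4, and whether moving the chlorine elsewhere on the benzyl ring would change the number.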